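A few compounds are considered here, and "the series" means these few. Any claim that something is new, unique, unknown or untested is made for them only; others in the source may bear on it.

Series notes, hydrazone aryl variation. Compound 1 `CN(C)CCn1cnnc1-c1cc(Oc2ccc(NC(=O)N/N=C/c3cccc(Cl)c3Cl)cc2F)ccn1` gives 130 nM in a functional assay on HT-29 cells (Homo sapiens) for cytotoxicity, read by MTT assay, with a stated time of 72 h; on this read-out lower numbers stand for stronger inhibition and higher numbers for weaker inhibition. Compound 2 `COc1cc(/C=N/NC(=O)Nc2ccc(Oc3ccnc(-c4nncn4CCN(C)C)c3)c(F)c2)ccc1O` gives 120 nM in this assay. The only step between them, a 1.1-fold lower number from compound 1 to compound 2 (0.03 log units; within the scatter), is within the scatter, so compound 2 stands level with compound 1 on the two numbers shown. Compound 3 `CN(C)CCn1cnnc1-c1cc(Oc2ccc(NC(=O)N/N=C/c3ccc(O)cc3O)cc2F)ccn1` differs from compound 2 by 2,4-dihydroxyphenyl in place of 4-hydroxy-3-methoxyphenyl on a carbon with a double bond to nitrogen. Within the data shown here, the single relevant step, a 1.1-fold lower number from compound 1 to compound 2 (0.03 log units; within the scatter), suggests the aryl group tolerates change here, so no step beyond the scatter is expected, a 1.1-fold higher number from compound 2 to compound 3 (0.03 log units; within the scatter). Compound 3 is estimated at 130 nM in this assay, with a range of 50 nM to 400 nM.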

Compound 3, half-maximal inhibitory concentration: 52600 nM
For compound 3 the middle estimate is 400-fold (2.61 log units) below the measured one, outside the stated range (above it).
By their numbers in this assay, from the lowest: compounds 2 and 1 (each within the scatter of the next); then compound 3.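

In this assay, 2,4-dihydroxyphenyl gives a 440-fold higher number from compound 2 to compound 3 (2.64 log units; beyond the scatter) and a 400-fold higher number from compound 1 to compound 3 (2.61 log units; beyond the scatter), so this place on a carbon with a double bond to nitrogen does not accept every aryl group. Among these compounds, the level values of compound 1 and compound 2 therefore showed only that those two groups match, not general tolerance, and compound 2 shows that one hydroxyl on the ring is compatible with the lower number. Nothing measured here accounts for the loss. From the compounds shown here alone, whether it follows the two hydroxyl groups or their arrangement stays open; a dimethoxyphenyl or aminophenyl group here would bear on that.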